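Swapping a Hydroxy(phenyl)methyl Group for Trifluoromethoxy

The source may report more compounds than this note shows. Statements on the series, on what has been measured and on what is new or still open speak of the compounds shown alone.

Compound 1 `CCS(=O)(=O)N(Cc1cccnc1)c1cccc(C(O)c2ccccc2)c1` was tested in an assay on isolated protein with metabotropic glutamate receptor 2 (Homo sapiens) as the target (a higher number here means that more compound is needed for the effect, a lower number that less compound is needed), and gave 2500 nM, the highest of the two numbers measured. Compound 2 `CCS(=O)(=O)N(Cc1cccnc1)c1cccc(Oc2ccccc2)c1`, which differs in one place, gave 360 nM in this assay, a step of a 6.9-fold lower number from compound 1 to compound 2 (0.84 log units; beyond the scatter). Compound 3 `CCS(=O)(=O)N(Cc1cccnc1)c1cccc(OC(F)(F)F)c1` carries a different change at the same spot: trifluoromethoxy in place of hydroxy(phenyl)methyl on an aromatic carbon. For the measured compounds named here, the one measured step, in which the hydroxy(phenyl)methyl group also left, bears on this, though the group entering here is not a phenoxy and has fewer heavy atoms. A drop of similar or somewhat smaller size is therefore expected, a 4.2-fold lower number from compound 1 to compound 3 (0.62 log units; beyond the scatter). Compound 3 is estimated at 600 nM, within 150 nM to 2500 nM.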

Compound 3, half-maximal effective concentration: 1600 nM
Compound 3: the middle estimate sits 2.7-fold (0.43 log units) below what was measured; the range from low to high includes it.
By their numbers in this assay, from the lowest: compound 2; then compounds 3 and 1 (each within the scatter of the next).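

Losing the hydroxy(phenyl)methyl group is not enough on its own in this assay: with trifluoromethoxy at this position, the two numbers stay within the scatter (a 1.6-fold lower number from compound 1 to compound 3 (0.19 log units; within the scatter)). An oxygen on the aromatic ring does not account for the result of compound 2 either, since the group on that oxygen matters: trifluoromethyl in place of phenyl gives (a 4.4-fold higher number from compound 2 to compound 3 (0.65 log units; beyond the scatter)). No measurement here explains these differences.

Still open, going by these compounds, is whether the phenyl ring itself counts or whether other groups on that oxygen would serve as well; a benzyl or cyclohexyl group there could help separate these possibilities.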